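This account rests on a few compounds, and the source may have more. Where it says the series, first, only, none or still open, it means among the compounds named here.

Among the measured compounds shown here, in a functional assay on NCI-H460 cells (Homo sapiens) for inhibition, with a stated time of 72 h (a higher number here means a weaker inhibitor, a lower number a stronger inhibitor), three compounds built on a shared core have numbers so far. Compound 1 (`COc1ccc(S(=O)(=O)N2CCc3cccc(-c4ccc(N)cc4)c32)cc1`) gives 288 nM, compound 2 (`COc1ccc(S(=O)(=O)N2CCc3cccc(-c4ccc([N+](=O)[O-])cc4)c32)cc1`) gives 53.1 nM, and compound 3 (`COc1ccc(S(=O)(=O)N2CCc3cccc(-c4cc(OC)c(OC)c(OC)c4)c32)cc1`) gives 6340 nM. Compound 2 therefore has the lowest number of the three and is the strongest inhibitor among them.

Compound 4 (`COc1ccc(S(=O)(=O)N2CCc3cccc(-c4ccc(F)cc4)c32)cc1`) has not yet been measured. It differs from compound 2 in one place, with fluoro in place of nitro on an aromatic carbon, para to a large group: fluoro in place of nitro on an aromatic carbon.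

For the measured compounds named here, only one measured step changes this same place: a 5.4-fold lower number from compound 1 to compound 2 (0.73 log units; beyond the scatter), with nitro in place of amino. That step is modest but beyond the scatter. Going by the values given here, it shows that this place can move the number, but no fluoro compound has been measured to show what that group does here. Compound 2 already sits lowest, so a modest rise seems more likely than a further drop.

The expected change is a 2.6-fold higher number from compound 2 to compound 4 (0.42 log units; beyond the scatter). For compound 4, the estimated value is 140 nM, with an expected range of 40 nM to 500 nM.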

Compound 4, half-maximal inhibitory concentration: 95.5 nM
For compound 4 the middle estimate is 1.5-fold (0.17 log units) above the measured one; measured number inside the range.
By their numbers in this assay, from the lowest: compounds 2 and 4 (each within the scatter of the next); then compound 1; then compound 3.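

With fluoro in place of nitro on the aromatic carbon para to a large group, this assay shows a 1.8-fold higher number from compound 2 to compound 4 (0.25 log units; within the scatter), so the two groups cannot be told apart here, although nitro counts hydrogen-bond acceptors and fluoro counts none. Fluoro in place of amino gives a 3.0-fold lower number from compound 1 to compound 4 (0.48 log units; beyond the scatter), which shows that nitro is not the only group measured at this place to give a lower number than amino. No measurement shown explains why these groups give these numbers.

From the compounds shown here alone, how a chloro group, a nitrile or a carboxylic acid would compare at this same place remains open. Compound 3 differs from the others in more than one place, so the contribution of each of its methoxy groups also remains unresolved.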